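This account rests on a few compounds, and the source may have more. Where it says the series, first, only, none or still open, it means among the compounds named here.

Measured compounds:
- compound 1 `CN(C)CCCCOc1ccc2oc(-c3ccccc3)cc(=O)c2c1`, in an assay on isolated protein (Cavia porcellus) with Sigma non-opioid intracellular receptor 1 (Homo sapiens) as the target, read by radioligand binding (on this read-out lower numbers stand for stronger inhibition and higher numbers for weaker inhibition), compound 1 gives 400 nM
- compound 2 `O=c1cc(-c2ccccc2)oc2ccc(OCCCCCCN3CCCC(O)C3)cc12`, in this assay compound 2 gives 77 nM

Within the data shown here, compound 2 stands at the lower of the two numbers; the gap to compound 1 is the only measured step, a 5.2-fold lower number from compound 1 to compound 2 (0.72 log units; beyond the scatter), and it lies beyond the scatter. That step, however, changes two things at once: the amine and the chain length, so neither can be separated on what is shown.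

Compound 3 `NCCCCCCOc1ccc2oc(-c3ccccc3)cc(=O)c2c1` keeps the six-bond chain of compound 2 and differs from it only at the chain end: amino in place of 3-hydroxypiperidin-1-yl on a saturated chain carbon, six bonds along the chain from an oxygen on an aromatic ring. Among the measured compounds shown here, no measured pair isolates this change. Both measured compounds carry a substituted nitrogen, and the only listed step was from dimethylamino to the ring-bearing amine while the chain also grew; the unsubstituted amine of compound 3 lies outside that range. Going from a ring-bearing tertiary amine to a bare amino group is expected to raise the number in this assay, by a step of about a 7.8-fold higher number from compound 2 to compound 3 (0.89 log units; beyond the scatter). Compound 3 is therefore estimated at 600 nM in this assay, within 150 nM to 2500 nM.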

Compound 3, half-maximal inhibitory concentration: 3700 nM
Compound 3: middle estimate off by 6.2-fold (0.79 log units), on the low side; the whole stated range lies below it.
By their numbers in this assay, from the lowest: compound 2; then compound 1; then compound 3.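

With the six-bond chain held constant, changing only the chain end gives a 48-fold higher number from compound 2 to compound 3 (1.68 log units; beyond the scatter) in this assay. This shows that the position six bonds along the chain from an oxygen on an aromatic ring responds strongly to amino in place of 3-hydroxypiperidin-1-yl, which the earlier step, with its amine and chain length changing together, could not show. The longer chain alone therefore does not secure the lower number: read as 2-aminoethyl in place of dimethylamino, four bonds along the chain from an oxygen on an aromatic ring, the change gives a 9.3-fold higher number from compound 1 to compound 3 (0.97 log units; beyond the scatter), the opposite direction to the step that introduced the ring-bearing amine. No independent evidence bears on this result.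

The compounds shown leave open whether the lower number of compound 2 belongs to the ring, its hydroxyl or the substitution on the nitrogen, a question that plain piperidin-1-yl or dimethylamino at the end of the same six-bond chain would divide. The contribution of chain length also remains unseparated, and reading it would take 3-hydroxypiperidin-1-yl on the shorter chain of compound 1, or a longer chain than that of compound 2.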